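This account rests on a few compounds, and the source may have more. Where it says the series, first, only, none or still open, it means among the compounds named here.

- compound 1 `Cc1ccc2[nH]c(-c3ccc(-c4ccc(-c5cccc(Cl)c5)cc4)cc3)nc2c1`: 2120 nM
- compound 2 `COc1ccc(-c2ccc(-c3ccc(-c4nc5cc(C)ccc5[nH]4)cc3)cc2)cc1OC`: 1310 nM
- compound 3 `COc1cc(-c2ccc(-c3ccc(-c4nc5cc(C)ccc5[nH]4)cc3)cc2)cc(OC)c1OC`: 170 nM

In a functional assay on Gurav cells (Homo sapiens) for inhibition, read by sulforhodamine B assay (on this read-out higher numbers stand for weaker inhibition of growth and lower numbers for stronger inhibition of growth), compound 1 stands at the upper end of these three numbers, though not alone. The nearest measured step is a 1.6-fold lower number from compound 1 to compound 2 (0.21 log units; within the scatter). Compound 3, at 170 nM, lies clearly lower.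

The next compound to be tested is compound 4 `Clc1cccc(-c2ccc(-c3ccc(-c4nc5ccccc5[nH]4)cc3)cc2)c1`. It differs from compound 1 in one place: hydrogen in place of methyl on an aromatic carbon. This is hydrogen in place of methyl on an aromatic carbon, in a six-membered aromatic ring of carbon only that is part of a fused system of two rings.

Neither measured step touches that place. One is a 1.6-fold lower number from compound 1 to compound 2 (0.21 log units; within the scatter), and the other is a 7.7-fold lower number from compound 2 to compound 3 (0.89 log units; beyond the scatter). The second shows that one small group can shift the number in this series, but both changes lie elsewhere, so the data offer no direct guide. No shift beyond the scatter is expected, and neither direction is favoured. The estimate, a 1.1-fold lower number from compound 1 to compound 4 (0.03 log units; within the scatter), therefore carries a wide range. Compound 4 is expected at 2000 nM, with an estimated range of 800 nM to 5000 nM.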

Compound 4, concentration for 50% growth inhibition: 2190 nM
Beside the measured number, compound 4's estimate is 1.1-fold (0.04 log units) below it; the measured number falls inside the stated range.
By their numbers in this assay, from the lowest: compound 3; then compounds 2, 1 and 4 (each within the scatter of the next).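

Hydrogen in place of methyl on an aromatic carbon of the fused system gives a 1.0-fold higher number from compound 1 to compound 4 (0.01 log units; within the scatter) in this assay. Among these compounds, this is the first reading at this position: with the 3-chlorophenyl group held fixed, the methyl can go without any change beyond the usual scatter, so this one swap does not shift the number the way the added methoxy did between the other compounds. No measurement among the data offered accounts for this result.

From the compounds shown here alone, whether the same swap would also leave the number in place on compound 3 stays open. So does the effect of a different kind of group on this carbon, such as an amine or a carboxylic acid, since only methyl and hydrogen are shown there.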